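This account rests on a few compounds, and the source may have more. Where it says the series, first, only, none or still open, it means among the compounds named here.

Measured so far in a functional assay for inhibition of nuclear factor NF-kappa-B complex (Homo sapiens); on this read-out lower numbers stand for stronger inhibition and higher numbers for weaker inhibition:
compound 1 `COc1ccc2c(c1)OC(c1cc(OC)c(OC)c(OC)c1)C(CO)=C2`: > 50000 nM.
compound 2 `COc1ccc2c(c1)OC(c1cc(OC)c(OC)c(OC)c1)C(C(=O)OC(C)C)=C2`: 11800 nM.
compound 3 `COc1ccc2c(c1)OC(c1cc(OC)c(OC)c(OC)c1)C(C(=O)Nc1ccccc1)=C2`: 17500 nM.

Compound 1 has only a limit of this assay, not a number; see (the limit of > 50000 nM in this assay, at which 1 of the 3 values shown sits). Compound 2 and compound 3 both give numbers, and the gap between them, a 1.5-fold higher number from compound 2 to compound 3 (0.17 log units; within the scatter), is within the scatter, so no order between the two is read.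

Compound 4 `COc1ccc2c(c1)OC(c1cc(OC)c(OC)c(OC)c1)C(C(=O)OCCc1ccccc1)=C2` is not yet measured. Its change from compound 1 is phenethyloxycarbonyl in place of hydroxymethyl on a double-bonded ring carbon. Going by the values given here, the steps that bear on it are an at least 4.2-fold lower number from compound 1 to compound 2 (0.62 log units; beyond the scatter) and an at least 2.8-fold lower number from compound 1 to compound 3 (0.45 log units; beyond the scatter), both at least modest and both going toward lower numbers once the hydroxymethyl is replaced. The phenethyloxycarbonyl group of compound 4 is closer to the isopropoxycarbonyl of compound 2 than to the phenylcarbamoyl of compound 3, so a step of the same kind is expected in this assay: lower numbers, at least modest, with no ground in the data for a step beyond what compound 2 and compound 3 showed.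

Compound 4 is therefore estimated at 12000 nM, with a range from 4000 nM to 35000 nM. The step this implies, an at least 4.1-fold lower number from compound 1 to compound 4 (0.61 log units; beyond the scatter), is expected to match the moves already seen from compound 1.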

Compound 4, half-maximal inhibitory concentration: 16200 nM
Beside the measured number, compound 4's estimate is 1.4-fold (0.13 log units) below it, and the stated range covers the measured number.
By their numbers in this assay, from the lowest: compounds 2, 4 and 3 (each within the scatter of the next). At a limit, above all of these: compound 1.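

In this assay, phenethyloxycarbonyl on this double-bonded ring carbon gives an at least 3.0-fold lower number from compound 1 to compound 4 (0.48 log units; beyond the scatter), so a third replacement of hydroxymethyl moves the same way as the two before it, now with an ester that carries a six-membered aromatic ring. The value for compound 1 is a limit and not a number: the limit of > 50000 nM in this assay, at which 1 of the 4 values shown sits. Phenethyl in place of isopropyl on the ester oxygen gives a 1.4-fold higher number from compound 2 to compound 4 (0.14 log units; within the scatter), and phenethyloxy in place of anilino on the carbonyl carbon gives a 1.1-fold lower number from compound 3 to compound 4 (0.03 log units; within the scatter), so neither change can be read as a difference, and compounds 2, 3 and 4 sit together.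

The compounds shown leave open whether a carboxylic acid, an amine or a shorter ester on this carbon would depart from that shared level. Going by these compounds, the full size of any step from compound 1 also stays open.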